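A Fluoromethyl Swap on a Weakly Cytotoxic Scaffold

The compounds below may be only part of what the source reports. "The series", "measured", "known", "first", "only" and "open" are said of these compounds alone.

Compound 3 `COC[C@@H](C)[C@@H](C)C(c1ccc(O)c(OC)c1)c1ccc(O)c(OC)c1` stands at the edge of what a functional assay on HeLa cells (Homo sapiens) for cytotoxicity, read by WST assay, with a stated time of 48 h (a higher number here means a weaker inhibitor, a lower number a stronger inhibitor), can report: in this assay compound 3 gives > 100000 nM, a limit rather than a number. Its mirror image, compound 1 `COC[C@H](C)[C@H](C)C(c1ccc(O)c(OC)c1)c1ccc(O)c(OC)c1`, gives 72000 nM in this assay. Going by the values given here, the only measured step, an at least 1.3-fold higher number from compound 1 to compound 3 (0.14 log units; that floor lies within the scatter), rests on the fact that compounds 1 and 3 differ only in the configuration as drawn and its floor lies within the scatter. Compound 2 `COc1ccc(C(c2ccc(OC)c(OC)c2)[C@@H](C)[C@H](C)CO)cc1OC` gives > 100000 nM in this assay, also a limit. Compound 4 `COc1cc(C(c2ccc(O)c(OC)c2)[C@@H](CF)C(C)C)ccc1O` differs from compound 3 by 1-(fluoromethyl)-2-methylpropyl in place of 2-(methoxymethyl)-1-methylpropyl on a saturated chain carbon bound to two aromatic carbons. Among the compounds with values here, no measured step touches this change, so no shift beyond the scatter is expected for compound 4, and the limit of > 100000 nM in this assay, at which 2 of the 3 values shown sit, makes another limit likely. Compound 4 is therefore estimated at 100000 nM, within 50000 nM to 300000 nM, an expected step of a number no higher from compound 3 to compound 4 (the limit leaves the size open).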

Compound 4, half-maximal inhibitory concentration: 41000 nM
Compound 4: middle estimate off by 2.4-fold (0.39 log units), on the high side; the measured number lies below the stated range.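

In this assay, going by these compounds alone, 1-(fluoromethyl)-2-methylpropyl in place of 2-(methoxymethyl)-1-methylpropyl gives the first step at this position that lies beyond the scatter: an at least 2.4-fold lower number from compound 3 to compound 4 (0.38 log units; beyond the scatter). Against the mirror-image partner, the same swap gives a 1.8-fold lower number from compound 1 to compound 4 (0.24 log units; within the scatter), so those two values cannot be told apart. The change therefore reads differently depending on the configuration of the starting compound.

Going by these compounds, it remains open whether the fluorine or the rest of the chain carries the step. On these data alone, how an amine or a longer chain would read at this place is also open.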